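The source may hold more compounds than are shown below. What is called first, only, known or untested is meant among the compounds shown, and "the series" means these compounds.

Measured in an ADME assay on microsomes from liver (Homo sapiens) for metabolic stability, with a stated time of 10 min; on this read-out higher numbers stand for a more stable compound and lower numbers for a less stable compound:
- compound 1 `FC(F)(F)c1ccccc1-c1ccc2[nH]c(C3=NOC4(CCCCC4)C3)nc2c1`: 100%
- compound 2 `FC(F)Oc1ccccc1-c1ccc2[nH]c(C3=NOC4(CCCCC4)C3)nc2c1`: 100%
- compound 3 `Fc1cccc(C(F)(F)F)c1-c1ccc2[nH]c(C3=NOC4(CCCCC4)C3)nc2c1`: 38%

Compound 1 shares the top of these three numbers with compound 2. The nearest step is no change at the digits printed from compound 1 to compound 2 (within the scatter), and the furthest is a number 62 percentage points lower from compound 1 to compound 3 (beyond the scatter).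

Not yet measured is compound 4 `Fc1cc(-c2ccccc2C(F)(F)F)cc2nc(C3=NOC4(CCCCC4)C3)[nH]c12`. Its difference from the parent is fluoro in place of hydrogen on an aromatic carbon, ortho to a fused ring and meta to a 2-(trifluoromethyl)phenyl group.

Going by the values given here, the closest precedent is the other fluoro for hydrogen swap, a number 62 percentage points lower from compound 1 to compound 3 (beyond the scatter). There the fluoro sits on the 2-(trifluoromethyl)phenyl group, whereas in compound 4 it sits on a ring that is part of a fused or bridged system of two rings. That single step gives a direction but no reliable size at the new place. The step of no change at the digits printed from compound 1 to compound 2 (within the scatter) involves a different change and bears only weakly on this one.

A smaller fall than in the compound 3 step is therefore expected, with a result within the scatter still possible. The expected step is a number 20 percentage points lower from compound 1 to compound 4 (beyond the scatter). For compound 4 the estimated value is 80%, with an estimated range of 45% to 100%.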

Compound 4, percent of the compound remaining: 46%
Beside the measured number, compound 4's estimate is 34 percentage points above it; the measured number falls inside the stated range.
By their numbers in this assay, from the lowest: compounds 3 and 4 (each within the scatter of the next); then compounds 1 and 2 (each within the scatter of the next).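

In this assay, fluoro in place of hydrogen on an aromatic carbon of the ring that is part of a fused or bridged system of two rings, ortho to a fused ring and meta to a 2-(trifluoromethyl)phenyl group, gives a number 54 percentage points lower from compound 1 to compound 4 (beyond the scatter), so this position is not a silent one for the change. The earlier fluoro swap, on the 2-(trifluoromethyl)phenyl group, gave a number 62 percentage points lower from compound 1 to compound 3 (beyond the scatter), so the large fall now appears at two separate places on compound 1, and no fluoro for hydrogen step among these compounds goes against it, although that is only two steps from a single parent. No measurement at hand accounts for the fall at this position.

Open, as far as these compounds go, is whether the loss belongs to fluoro alone or would follow any group on this carbon, such as chloro, methyl, methoxy or an amine. Also open, from the compounds shown here alone, is how the other aromatic carbons of this ring respond to the same swap.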